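Urea-to-oxalamide change on the shared core

This account rests on a few compounds, and the source may have more. Where it says the series, first, only, none or still open, it means among the compounds named here.

Compound 1 `COc1ccc(/C(=C(/CCN=[N+]=[N-])c2ccccc2)c2ccccc2)cc1` is recorded as "not active" (no number reported) in a functional assay on MCF7 cells (Homo sapiens) for cytotoxicity, read by MTT assay, with a stated time of 72 h; a lower number here means a stronger inhibitor, a higher number a weaker inhibitor. Compound 2 `COc1ccc(/C(=C(/CCNC(=O)NC2CCCCC2)c2ccccc2)c2ccccc2)cc1` gives 37200 nM in this assay. Compound 3 `COc1ccc(/C(=C(/CCNC(=O)N2CCCCC2)c2ccccc2)c2ccccc2)cc1` reaches only > 50000 nM in this assay, which is a limit and not a number. Going by the values given here, the one measured step is an at least 1.3-fold higher number from compound 2 to compound 3 (0.12 log units; that floor lies within the scatter), and its floor lies within the scatter. the limit of > 50000 nM in this assay, at which 1 of the 3 values shown sits, marks where compound 3 sits, alongside one further entry without a number. Compound 4 `COc1ccc(/C(=C(/CCNC(=O)C(=O)N2CCCC2)c2ccccc2)c2ccccc2)cc1` differs from compound 3 by (pyrrolidin-1-yl)carbonyl in place of piperidin-1-yl on a carbonyl carbon. Among the compounds with values here, no measured step touches this change, and the only neighbouring step ran towards the limit, so no shift beyond the scatter is expected in this assay, and a limit again seems likely. Compound 4 is estimated at 60000 nM with a range of 25000 nM to 150000 nM. The expected step is a step that the limit leaves unreadable from compound 3 to compound 4.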

Compound 4, half-maximal inhibitory concentration: > 50000 nM
Compound 4: a limit, no number; the forecaster's own chance of this, stated with the estimate: 65%; the middle value is on the limit's open side.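

Replacing piperidin-1-yl with (pyrrolidin-1-yl)carbonyl on this carbonyl carbon does not bring the series off the limit, and compound 4 is also a limit and not a number in this assay: the limit of > 50000 nM in this assay, at which 2 of the 4 values shown sit.

The step between the two limits cannot be read. Against the only compound here with a number, the change gives an at least 1.3-fold higher number from compound 2 to compound 4 (0.12 log units; that floor lies within the scatter), so no loss beyond the scatter can be claimed.

Still open, from the compounds shown here alone, is how far compound 3 and compound 4 lie from the limit. Also open, going by these compounds, is whether a primary amine or a carboxylic acid on this chain would give a number in this assay.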